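Swapping Methoxy for Dimethylamino in Compound 1

The source may hold more compounds than are shown below. What is called first, only, known or untested is meant among the compounds shown, and "the series" means these compounds.

In an ADME assay on J774.A1 cells (Mus musculus) for cytotoxicity, read by MTT assay, with a stated time of 48 h (on this read-out higher numbers stand for lower toxicity in this test and lower numbers for higher toxicity in this test), compound 1 (`COc1ccc(/C=C(\C)C(=O)/C=C/c2ccc([N+](=O)[O-])cc2)cc1`) gives 30000 nM. Among the measured compounds shown here, its only measured neighbour, compound 2 (`COc1ccc(/C=C(\C)C(=O)/C=C/c2ccc(N(C)C)cc2)cc1`), gives 36200 nM, and the measured change is a 1.2-fold higher number from compound 1 to compound 2 (0.08 log units; within the scatter). The two numbers cannot be ranked, so compound 1 shares a single narrow band with compound 2.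

Compound 3 (`C/C(=C\c1ccc(N(C)C)cc1)C(=O)/C=C/c1ccc([N+](=O)[O-])cc1`) has not yet been measured. It differs from compound 1 by one change, (dimethylamino in place of methoxy on an aromatic carbon), with dimethylamino in place of methoxy on an aromatic carbon. For the measured compounds named here, only one measured step bears on this. The group entering in a 1.2-fold higher number from compound 1 to compound 2 (0.08 log units; within the scatter) is also dimethylamino, but there it replaced nitro rather than methoxy, so the evidence is indirect. Going by the values given here, compound 3 also carries dimethylamino together with nitro, a pairing that no measured compound has, and this calls for a generous range.

No shift beyond the scatter is therefore expected in this assay, and the estimated change is no change at the digits printed from compound 1 to compound 3 (within the scatter). For compound 3 the expected value is 30000 nM, with an estimated range from 14000 nM to 62000 nM.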

Compound 3, half-maximal cytotoxic concentration: 967000 nM
Compound 3: middle estimate off by 32-fold (1.51 log units), on the low side, outside the stated range (above it).
By their numbers in this assay, from the lowest: compounds 1 and 2 (each within the scatter of the next); then compound 3.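

In this assay, this aromatic carbon, para to a large group, proves highly sensitive to its substituent: dimethylamino in place of methoxy gives a 32-fold higher number from compound 1 to compound 3 (1.51 log units; beyond the scatter), a large move towards lower toxicity in this test. The earlier step, a 1.2-fold higher number from compound 1 to compound 2 (0.08 log units; within the scatter), brought in the same dimethylamino in place of nitro and stayed within the scatter, so the entering group does not by itself set the outcome; what matters is where it enters and which group it replaces. No measurement here accounts for the large shift.

The compounds shown leave open whether a primary amine, a hydroxyl or a diethylamino group on this carbon would raise the number as far, and so whether the rise follows from dimethylamino specifically or from the loss of methoxy. They also leave open whether the rise depends on the nitro group that compound 3 retains, or would recur with a different group, such as a chlorine atom or a carboxylic acid, in that place.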